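From a Fluorophenyl to a Trimethylphenyl on the Shared Core

The source may hold more compounds than are shown below. What is called first, only, known or untested is meant among the compounds shown, and "the series" means these compounds.

Of the compounds shown here, three have been measured. Compound 1 `Oc1c(C(c2ccc(F)cc2)N2CCCCC2)ccc2scnc12` gives 570 nM in an assay for inhibition of protein disulfide-isomerase (Homo sapiens), with a stated time of 1 h; a lower number here means a stronger inhibitor, a higher number a weaker inhibitor. Compound 2 `Oc1c(C(Nc2ccccn2)c2ccccc2F)ccc2cccnc12` gives 470 nM in this assay. Compound 3 `Cc1ccnc(NC(c2ccccc2F)c2ccc3cccnc3c2O)c1` gives 880 nM in this assay.

Compound 2 carries the smallest number of the three, but the gap to compound 1 and the step of a 1.9-fold higher number from compound 2 to compound 3 (0.27 log units; within the scatter) both lie within the scatter, so the three cannot be told apart on these numbers.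

Compound 4 `Cc1cc(C)c(C(Nc2ccccn2)c2ccc3cccnc3c2O)c(C)c1` has not been measured. It differs from compound 2 in one place: 2,4,6-trimethylphenyl in place of 2-fluorophenyl on a saturated chain carbon bound to an aromatic carbon and a nitrogen on an aromatic ring. Among the measured compounds shown here, the only measured step, a 1.9-fold higher number from compound 2 to compound 3 (0.27 log units; within the scatter), adds a methyl on an aromatic carbon of a different ring and leaves the aryl group untouched; no measured step exchanges the aryl group on that saturated carbon. That lone step was within the scatter, which hints that small additions on the periphery of compound 2 are tolerated, but the exchange in compound 4 is larger than anything measured, so the expectation is loose.

The step of a 1.6-fold higher number from compound 2 to compound 4 (0.20 log units; within the scatter) is expected to be small, leaning toward a higher number. Compound 4 is therefore estimated at 750 nM, within a range of 250 nM to 2500 nM.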

Compound 4, half-maximal inhibitory concentration: 190 nM
The estimate for compound 4 lay 3.9-fold (0.60 log units) above the measured number; the whole stated range lies above it.
By their numbers in this assay, from the lowest: compound 4; then compounds 2, 1 and 3 (each within the scatter of the next).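

At the saturated chain carbon bound to an aromatic carbon and a nitrogen on an aromatic ring, exchanging 2-fluorophenyl for 2,4,6-trimethylphenyl in this assay gives a 2.5-fold lower number from compound 2 to compound 4 (0.39 log units; beyond the scatter) and is the first step among these compounds to lie beyond the scatter, though only modestly. Among the compounds shown here, the earlier step, a 1.9-fold higher number from compound 2 to compound 3 (0.27 log units; within the scatter) on another ring, could not be told from the scatter, so this position is the first place where a single change is seen to move the number. The entering group has more heavy atoms than the one it replaces, nine carbons against six carbons and a fluorine, and the number still goes down, so in this pair a bigger aryl group at this position does not cost activity. Nothing available here bears on the reason for this step.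

The compounds shown leave open whether the gain goes with the three methyl groups or with the loss of the fluorine, which a plain phenyl or a phenyl carrying a single methyl would help to separate. They also leave open how far the position can be pushed, for instance with a cyclohexyl or a naphthyl group, and whether the same exchange holds on compound 3.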